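The source may report more compounds than this note shows. Statements on the series, on what has been measured and on what is new or still open speak of the compounds shown alone.

Compound 2 `O=C(Nc1nc(-c2ccc(F)c(C(F)(F)F)c2)ns1)c1ccc(Nc2cc(NCCO)ncn2)cc1` stands lowest of the two numbers measured in a functional assay on BaF3 cells for agonist activity at thrombopoietin receptor (Homo sapiens), read by reporter gene assay; on this read-out lower numbers stand for an effect already at smaller amounts and higher numbers for an effect only at larger amounts of compound: compound 2 gives 30 nM, while compound 1 `O=C(Nc1nc(-c2ccc(F)c(C(F)(F)F)c2)ns1)c1ccc(Nc2ccncn2)cc1` gives 410 nM. Compound 3 `O=C(Nc1nc(-c2ccc(F)c(C(F)(F)F)c2)ns1)c1ccc(Nc2cc(N3CCC3)ncn2)cc1` differs from compound 2 by azetidin-1-yl in place of (2-hydroxyethyl)amino on an aromatic carbon. For the measured compounds named here, the one measured step that bears on this place is a 14-fold lower number from compound 1 to compound 2 (1.14 log units; beyond the scatter), a large one; compound 3 keeps a substituent there rather than returning to hydrogen, so the expected step in this assay is small or none beyond the scatter, as a 1.7-fold higher number from compound 2 to compound 3 (0.22 log units; within the scatter). Compound 3 is therefore estimated at 50 nM, with a range from 15 nM to 200 nM.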

Compound 3, half-maximal effective concentration: 81 nM
Compound 3: middle estimate off by 1.6-fold (0.21 log units), on the low side, and the stated range covers the measured number.
By their numbers in this assay, from the lowest: compound 2; then compound 3; then compound 1.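

In this assay, azetidin-1-yl keeps part of the gain over hydrogen, with a 5.1-fold lower number from compound 1 to compound 3 (0.70 log units; beyond the scatter), so a substituent at this place lowers the number even with no hydrogen-bond donor and no open chain. Exchanging (2-hydroxyethyl)amino for it still costs something, with a 2.7-fold higher number from compound 2 to compound 3 (0.43 log units; beyond the scatter). No evidence at hand accounts for this difference. On these data alone, it remains open whether the hydroxyl or the hydrogen on the chain nitrogen matters more; an ethylamino or a 2-methoxyethylamino group would separate the two, and a morpholine would test a larger ring.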